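This account rests on a few compounds, and the source may have more. Where it says the series, first, only, none or still open, it means among the compounds named here.

This account follows a single change made to compound 1, whose structure is `Cn1ncc(Cl)c1-c1cc(C(=O)N[C@@H]2CN[C@H](CC(O)CO)C[C@H]2c2ccc(Cl)c(Cl)c2)oc1Cl`. In a functional assay on HCT-116 cells (Homo sapiens) for antiproliferative activity, read by sulforhodamine B assay, with a stated time of 72 h (on this read-out lower numbers stand for stronger inhibition and higher numbers for weaker inhibition), compound 1 gives 1110 nM, the highest number among the three measured compounds. Its nearest neighbour is compound 3, `C=CC[C@@H]1C[C@@H](c2ccc(Cl)c(Cl)c2)[C@H](NC(=O)c2cc(-c3c(Cl)cnn3C)c(Cl)o2)CN1`, and compound 3 gives 780 nM in this assay. Furthest from it is compound 2, `Cn1ncc(Cl)c1-c1cc(C(=O)N[C@@H]2CN[C@H](CCO)C[C@H]2c2ccc(F)c(F)c2)oc1Cl`; compound 2 gives 360 nM, a number beyond the scatter from that of compound 1, but compound 2 differs from compound 1 in more than one place, so no single step can be drawn between them.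

The new compound is compound 4, with the structure `Cn1ncc(Cl)c1-c1cc(C(=O)N[C@@H]2CN[C@H](CC(=O)NC3CC3)C[C@H]2c2ccc(Cl)c(Cl)c2)oc1Cl`. How it differs from compound 1:

cyclopropylcarbamoyl in place of 1,2-dihydroxyethyl on a saturated chain carbon bound to a saturated ring carbon

Going by the values given here, only one measured step touches the same place, the saturated chain carbon bound to a saturated ring carbon: a 1.4-fold lower number from compound 1 to compound 3 (0.15 log units; within the scatter), where vinyl replaced 1,2-dihydroxyethyl and the number stayed within the scatter. That step gives no sign that swapping this group shifts the read-out much in either direction, although cyclopropylcarbamoyl itself has not been measured here. The expectation for compound 4 is therefore a step of a 1.2-fold lower number from compound 1 to compound 4 (0.09 log units; within the scatter), none beyond the scatter. Compound 4 is thus estimated at 900 nM in this assay, with a range from 400 nM to 2500 nM.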

Compound 4, half-maximal inhibitory concentration: 740 nM
Compound 4: middle estimate off by 1.2-fold (0.09 log units), on the high side, and the stated range covers the measured number.
By their numbers in this assay, from the lowest: compound 2; then compounds 4, 3 and 1 (each within the scatter of the next).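

In this assay, the step to the new group is a 1.5-fold lower number from compound 1 to compound 4 (0.18 log units; within the scatter), even though cyclopropylcarbamoyl brings a three-membered ring and a carbonyl and has more heavy atoms and fewer hydrogen-bond donors and acceptors than 1,2-dihydroxyethyl. Going by these compounds alone, measured against the other replacement, the step is a 1.1-fold lower number from compound 3 to compound 4 (0.02 log units; within the scatter), so 1,2-dihydroxyethyl, vinyl and cyclopropylcarbamoyl, three quite different groups on a saturated chain carbon bound to a saturated ring carbon, all stand within the scatter of one another, where the earlier compounds offered only a single such comparison. No measurement at hand explains why the read-out stays so level across these groups.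

From the compounds shown here alone, whether any group at this place can move the number beyond the scatter remains open, as an amine, a carboxylic acid or a longer chain ending in a basic nitrogen might behave differently from these three. Compound 2 gives 360 nM, but it differs from these compounds in more than one place, so its number cannot be credited to any single group.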